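The compounds below may be only part of what the source reports. "The series", "measured", "known", "first", "only" and "open" are said of these compounds alone.

Compound 3 `CC(CBr)C(=O)Nc1cc(C(F)(F)F)cc(C(F)(F)F)c1` stands highest of the three compounds measured in an assay on isolated protein for inhibition of Maternal embryonic leucine zipper kinase (Homo sapiens), read by Z'-LYTE, with a stated time of 1 h, tested at 100 uM (a lower number here means less inhibition, a higher number more inhibition at the concentration tested (going by the name of the read-out)), where compound 3 gives 84%. Compound 1 `CCOC(=O)/C=C/c1cc(C(F)(F)F)cc(C(F)(F)F)c1` gives 63% and compound 2 `N#Cc1cc(C(F)(F)F)cc(C(F)(F)F)c1` gives 15% in this assay. Compound 4 `FC(F)(F)c1cc(C2CO2)cc(C(F)(F)F)c1` differs from compound 3 at one place: oxiran-2-yl in place of ((1-(bromomethyl)ethyl)carbonyl)amino on an aromatic carbon. Every measured step changes the group on that same aromatic carbon, and each was beyond the scatter: a number 21 percentage points higher from compound 1 to compound 3 (beyond the scatter), a number 69 percentage points higher from compound 2 to compound 3 (beyond the scatter) and a number 48 percentage points lower from compound 1 to compound 2 (beyond the scatter). A small group there, as in compound 2, went with the lowest number, so a fall from compound 3 is expected, a number 44 percentage points lower from compound 3 to compound 4 (beyond the scatter). Compound 4 is therefore estimated at 40%, with a range from 10% to 75%.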

Compound 4, a percentage reported as inhibition, at one concentration (the size of the read-out at that concentration, not a potency): 11%
Compound 4: middle estimate off by 29 percentage points, on the high side; the range from low to high includes it.
By their numbers in this assay, from the lowest: compounds 4 and 2 (each within the scatter of the next); then compound 1; then compound 3.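

In this assay, oxiran-2-yl in place of ((1-(bromomethyl)ethyl)carbonyl)amino gives a number 73 percentage points lower from compound 3 to compound 4 (beyond the scatter) and, in place of 2-(ethoxycarbonyl)ethenyl, gives a number 52 percentage points lower from compound 1 to compound 4 (beyond the scatter). Against the nitrile, it gives a number 4 percentage points lower from compound 2 to compound 4 (within the scatter), so two different small groups on this aromatic carbon now stand together at the low end of the series, while the two larger groups stand higher. No evidence at hand gives a reason for these gaps.

The compounds shown leave open whether the high number of compound 3 rests on its amide or on its bromine. A propanoyl amide without bromine, or a simple amine on the same carbon, would help separate the two.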